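Hydroxy in place of bromo on compound 3

The source may report more compounds than this note shows. Statements on the series, on what has been measured and on what is new or still open speak of the compounds shown alone.

In a physicochemical assay for lipophilicity, measured as octanol-water partition (on this read-out lower numbers stand for lower lipophilicity and higher numbers for higher lipophilicity), compound 1 (`C/C(=N\NC(=O)COc1cccc2ccccc12)c1ccc([N+](=O)[O-])cc1`) reads 3.37 while compound 2 (`C/C(=N\NC(=O)COc1cccc2ccccc12)c1ccc(O)cc1O`) reads 4.31 and compound 3 (`C/C(=N\NC(=O)COc1cccc2ccccc12)c1ccc(Br)cc1`) reads 3.61 on the same scale. Compound 3 thus stands within the scatter of compound 1 (a number 0.24 log units higher from compound 1 to compound 3 (within the scatter)) and clearly under compound 2 (a number 0.70 log units lower from compound 2 to compound 3 (beyond the scatter)). Compound 4 (`C/C(=N\NC(=O)COc1cccc2ccccc12)c1ccc(O)cc1`) carries hydroxy in place of bromo on an aromatic carbon, which reads as 4-bromophenyl to 4-hydroxyphenyl. Among the compounds with values here, the only measured compound bearing hydroxy is compound 2, whose modest step (a number 0.94 log units higher from compound 1 to compound 2 (beyond the scatter)) offers a weak guide. Within the data shown here, no measured compound carries 4-hydroxyphenyl alone, so only a small rise is expected. The expected step (a number 0.14 log units higher from compound 3 to compound 4 (within the scatter)) is estimated to stay within the scatter. Compound 4 is estimated at 3.75 (expected range 3.25 to 4.3).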

Compound 4, partition coefficient: 4.44
For compound 4 the middle estimate is 0.69 log units below the measured one, and the stated range ends below it.
By their numbers in this assay, from the lowest: compounds 1 and 3 (each within the scatter of the next); then compounds 2 and 4 (each within the scatter of the next).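

In this assay, hydroxy in place of bromo on this aromatic carbon gives a real change (a number 0.83 log units higher from compound 3 to compound 4 (beyond the scatter)), and hydroxy in place of nitro at the same place gives a large one (a number 1.07 log units higher from compound 1 to compound 4 (beyond the scatter)). Hydrogen in place of the other hydroxy of compound 2 leaves the reading within the scatter (a number 0.13 log units higher from compound 2 to compound 4 (within the scatter)), so the 4-hydroxyphenyl compound reads level with the 2,4-dihydroxyphenyl compound.

Nothing available explains why hydroxy reads higher here than bromo or nitro. On these data alone, whether a methoxy or an amine at this place would read with the hydroxy compounds or with the bromo and nitro compounds stays open.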